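Amide nitrogen substituent changes in a dopamine transporter series

The source may report more compounds than this note shows. Statements on the series, on what has been measured and on what is new or still open speak of the compounds shown alone.

Measured compounds and values:
compound 1, `C=CCN(CCOC)C(=O)[C@@]1(c2ccsc2)C[C@H]1CN`: in an assay on HEK293 cells for inhibition of sodium-dependent dopamine transporter (Homo sapiens) (a lower number here means a stronger inhibitor, a higher number a weaker inhibitor), compound 1 gives > 10000 nM, a limit of the assay.
compound 2, `C=C(F)CN(C)C(=O)[C@@]1(c2ccsc2)C[C@H]1CN`: in this assay compound 2 gives > 10000 nM, also a limit.
compound 3, `COCCN(C)C(=O)[C@@]1(c2ccsc2)C[C@H]1CN`: in this assay compound 3 gives > 10000 nM, again a limit.

For the measured compounds named here, compound 1 stands at the limit of the assay, and it is not alone there: the limit of > 10000 nM in this assay, at which 3 of the 3 values shown sit, records that every value shown sits at that same limit, so no compound in the set separates from another. The two measured steps at the amide-type nitrogen, a step that the two limits leave unreadable from compound 1 to compound 3 and a step that the two limits leave unreadable from compound 2 to compound 3, are therefore unreadable; they tell only that exchanging vinyl for hydrogen, or 1-fluoroethenyl for methoxymethyl, left the compounds at the limit.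

Compound 4, `C#CCN(CC=C)C(=O)[C@@]1(c2ccsc2)C[C@H]1CN`, differs from compound 1 by ethynyl in place of methoxymethyl on a saturated chain carbon bound to an amide-type nitrogen. Both measured steps bear on it in that they change the same position, but neither gives a size or direction to carry over. With compound 1 at the limit, the expectation is that compound 4 also gives no readable value; the step that the limit leaves unreadable from compound 1 to compound 4 is estimated as no change that the assay could show. For compound 4 in this assay the estimate is 15000 nM, with a range from 3000 nM to 60000 nM.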

Compound 4, half-maximal inhibitory concentration: > 10000 nM
Compound 4 gave a limit, no number; the forecaster's own chance of this, stated with the estimate: 80%; the middle value lies beyond the limit too.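

In this assay compound 4 gives > 10000 nM, a limit of the assay and not a number. No new step can be read between compound 1 and compound 4, as both stand at the same limit: the limit of > 10000 nM in this assay, at which 4 of the 4 values shown sit.

The compounds shown leave open whether any substituent on the amide-type nitrogen gives a measurable value.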